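This account rests on a few compounds, and the source may have more. Where it says the series, first, only, none or still open, it means among the compounds named here.

Measured so far:
- Compound 1, `Cc1ccc(CC(Oc2ccc(C(C)C)cc2)C(=O)O)cc1`: in a functional assay on the whole organism for inhibition, with Rattus norvegicus as the target (a lower number here means that less compound is needed, a higher number that more compound is needed for the effect), compound 1 gives < 50 mg/kg, which is a limit of the assay and not a number.
- Compound 2, `COc1ccc(CC(Oc2ccc(C(C)C)cc2)C(=O)O)cc1`: in this assay compound 2 gives > 50 mg/kg, again a limit and not a number.
- Compound 3, `Cc1ccc(OC(Cc2ccc(Cl)cc2)C(=O)O)cc1`: in this assay compound 3 gives > 25 mg/kg, also a limit and not a number.

Compound 1 and compound 2 share a core and differ in one place: methoxy in place of methyl on an aromatic carbon. Going by these compounds, the step of a number no lower from compound 1 to compound 2 (the limit leaves the size open) is a move from one limit to another, so its size stays open; the two limits themselves are the limit of < 50 mg/kg in this assay, at which 1 of the 3 values shown sits, and (the limit of > 50 mg/kg in this assay, at which 1 of the 3 values shown sits). The limit for compound 3 is the limit of > 25 mg/kg in this assay, at which 1 of the 3 values shown sits.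

Compound 3 rests on a different core from compound 1; the difference between the two cores is not broken down here.

Compound 4, `COc1ccc(OC(Cc2ccc(Cl)cc2)C(=O)O)cc1`, has not yet been tested in this assay. It stands to compound 3 exactly as compound 2 stands to compound 1: methoxy in place of methyl on an aromatic carbon. Since the places of both changes are described in the same words, this is the same change, made a second time.

The step that the limit leaves unreadable from compound 3 to compound 4 is the size expected here, and it rests on compound 3 already sitting at a limit with > 25 mg/kg and on the earlier change having given a number no lower in a number no lower from compound 1 to compound 2 (the limit leaves the size open). Compound 4 is therefore expected to need a dose of about 80 mg/kg, most likely reported only as a limit, with a range estimated from 30 mg/kg to 300 mg/kg.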

Compound 4, dose for half-maximal effect: > 25 mg/kg
Compound 4 gave a limit, no number; the forecaster's own chance of this, stated with the estimate: 80%; the middle value does not contradict the limit.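

In this assay compound 4 gives > 25 mg/kg, which is a limit of the assay and not a number. Compound 3 also sits at a limit, so no step can be read between compound 3 and compound 4. The compounds shown leave open how far methoxy in place of methyl shifts the dose on either core, and what dose compound 3 and compound 4 actually need.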